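Swapping the ketone aryl ring on a chalcone hydrazone

This account rests on a few compounds, and the source may have more. Where it says the series, first, only, none or still open, it means among the compounds named here.

Measured compounds:
Compound 1 `O=C(/C=C/c1ccc(/C=N/NC(=O)c2ccncc2)cc1)c1ccc(F)cc1` gives 51.1% in a functional assay on the whole organism (Ear) for inhibition, with Mus musculus as the target, with a stated time of 30 min, at a dose of 100 mg/kg by the intraperitoneal route; on this read-out higher numbers stand for more inhibition at the one dose given (going by the name of the read-out) and lower numbers for less inhibition.
Compound 2 `COc1ccc(C(=O)/C=C/c2ccc(/C=N/NC(=N)N)cc2)cc1` gives 57.2% in this assay.
Compound 3 `O=C(N/N=C/c1ccc(/C=C/C(=O)c2ccccc2Cl)cc1)c1cccc(Cl)c1` gives 43% in this assay.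

Among these three numbers compound 2 holds the highest one. The gap to compound 1 is within the usual scatter of this kind of measurement, so the two cannot be ranked against each other. Within the data shown here, compound 3 sits clearly lower, beyond the scatter, and is the only compound here to carry a halogen on the phenyl ring attached to the carbonyl. No two of the measured compounds differ in just one place, so no single step can be read directly from them.

Compound 4 `N=C(N)N/N=C/c1ccc(/C=C/C(=O)c2ccccc2Br)cc1` has not yet been measured. It is built from compound 2 by one change: 2-bromophenyl in place of 4-methoxyphenyl on a carbonyl carbon. The closest measured hint is compound 3, which also carries a halogen on that ring and gives 43%, though compound 3 differs from compound 4 at the other end of the molecule as well.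

Compound 4 is expected to land somewhat lower than compound 2, with a step of a number 10.2 percentage points lower from compound 2 to compound 4 (beyond the scatter), moderate in size and perhaps just beyond the scatter. The estimate for compound 4 is 47%, within a range of 34% to 60%.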

Compound 4, a percentage reported as inhibition, in the whole organism at one dose (the size of the read-out at that dose, not a potency): 78.3%
Beside the measured number, compound 4's estimate is 31.3 percentage points below it; measured number above the stated range.
By their numbers in this assay, from the lowest: compounds 3, 1 and 2 (each within the scatter of the next, the first and the last beyond it); then compound 4.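

Among these compounds, replacing 4-methoxyphenyl with 2-bromophenyl on a carbonyl carbon gives the first step in this set that can be read at a single place, a number 21.1 percentage points higher from compound 2 to compound 4 (beyond the scatter), in this assay. With the rest of the molecule held the same, this shows that the group on this carbonyl carbon can by itself move the inhibition at the one dose given by more than the scatter, and that the hydrogen-bond acceptor counted in 4-methoxyphenyl is not needed for the higher number in this pair. Nothing measured here gives a reason for the size or direction of this step.

This single pair changes the ring's substituent and its place together, so it leaves open whether the gain belongs to the bromine or to where the group stands, a question that 4-bromophenyl, 2-chlorophenyl, 2-methoxyphenyl or plain phenyl on the same carbonyl carbon would bear on. It also leaves open whether the same swap would give a similar step with the aroyl hydrazone end of compound 1 or compound 3 in place of the end shared by compound 2 and compound 4.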